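This account rests on a few compounds, and the source may have more. Where it says the series, first, only, none or still open, it means among the compounds named here.

Compound 1 `COc1cccc(Oc2c(NS(=O)(=O)c3ccc(C(C)(C)C)cc3)ncnc2OCCOc2ccccc2)c1` gives the highest of the two numbers recorded in an assay on cells (Endothelial cell) for binding affinity to Endothelin-1 receptor (Sus scrofa) (a higher number here means a weaker inhibitor, a lower number a stronger inhibitor), namely 65 nM. Its nearest neighbour, compound 2 `COc1cccc(Oc2c(NS(=O)(=O)c3ccc(C(C)(C)C)cc3)ncnc2OCCOc2nccs2)c1`, gives 12 nM in this assay, and the step of a 5.4-fold lower number from compound 1 to compound 2 (0.73 log units; beyond the scatter) shows that a 1,3-thiazol-2-yl in place of phenyl on an oxygen on a saturated carbon lowers the number. Compound 3 `COc1cccc(Oc2c(NS(=O)(=O)c3ccc(C(C)(C)C)cc3)ncnc2SCCOc2ncccn2)c1` differs from compound 1 as follows: (2-((pyrimidin-2-yl)oxy)ethyl)sulfanyl in place of 2-phenoxyethoxy on an aromatic carbon. For the measured compounds named here, the step from compound 1 to compound 2 bears on this change, since both put a heteroaromatic ring where the phenyl stood; the sulfanyl link in place of the ethoxy link has no measured counterpart, so its effect is unknown. Compound 3 is therefore expected to give a somewhat lower number than compound 1, an estimated step of a 2.6-fold lower number from compound 1 to compound 3 (0.41 log units; beyond the scatter). For compound 3 the estimate in this assay is 25 nM, within a range of 8 nM to 80 nM.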

Compound 3, half-maximal inhibitory concentration: 25.8 nM
Estimate against measurement, compound 3: 1.0-fold (0.01 log units) below; low and high end bracket the measured number.
By their numbers in this assay, from the lowest: compound 2; then compound 3; then compound 1.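

In this assay the position on the aromatic carbon next to the ring nitrogen takes (2-((pyrimidin-2-yl)oxy)ethyl)sulfanyl in place of 2-phenoxyethoxy with a 2.5-fold lower number from compound 1 to compound 3 (0.40 log units; beyond the scatter) and so a chain joined through sulfur, carrying a pyrimidine ring, still gives a lower number than the phenyl ether chain of compound 1. Against the 2-((1,3-thiazol-2-yl)oxy)ethoxy chain the same group gives a 2.2-fold higher number from compound 2 to compound 3 (0.33 log units; beyond the scatter) and so compound 2 keeps the lowest number of the three. Nothing shown here accounts for the size of either step.

Compound 3 changes the linking atom and the ring together, so the share of each in its step stays unresolved. As far as these compounds go, how an amine or a carboxylic acid at the end of this chain, or a longer chain, would behave at this position also remains open.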